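A Chloro for a Methoxy on the Outer Phenyl Ring

The source may report more compounds than this note shows. Statements on the series, on what has been measured and on what is new or still open speak of the compounds shown alone.

Two compounds have been measured in a functional assay on cells (Melanoma cell, Homo sapiens) for cytotoxicity, read by sulforhodamine B assay, with a stated time of 48 h; a higher number here means a weaker inhibitor of growth, a lower number a stronger inhibitor of growth:

Compound 1, `O=C1N=C(N2N=C(c3ccccc3)CC2c2ccccc2O)S/C1=C1/C(=O)Nc2ccccc21`, gives 2040 nM.
Compound 2, `COc1ccc(C2CC(c3ccccc3)=NN2C2=NC(=O)/C(=C3\C(=O)Nc4ccccc43)S2)cc1`, gives 2000 nM.

These two differ in one place only, on a saturated ring carbon, where compound 2 carries a 4-methoxyphenyl in place of the 2-hydroxyphenyl of compound 1; the step of a 1.0-fold lower number from compound 1 to compound 2 (0.01 log units; within the scatter), so the two values cannot be told apart. Compound 2 thus holds the lower of the two numbers, but its nearest neighbour, compound 1, sits within the scatter of it, and no order between them can be claimed.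

Compound 3, `O=C1N=C(N2N=C(c3ccccc3)CC2c2ccc(Cl)cc2)S/C1=C1/C(=O)Nc2ccccc21`, keeps the shared core and changes only the outer phenyl ring: chloro in place of methoxy on an aromatic carbon. Read one bond further out, a 4-methoxyphenyl becomes a 4-chlorophenyl. For the measured compounds named here, no measured step touches this exchange. Going by the values given here, the one step known, from 2-hydroxyphenyl to 4-methoxyphenyl, was within the scatter, and nothing in the numbers points in either direction. The expectation for compound 3 in this assay is therefore a step of no change at the digits printed from compound 2 to compound 3 (within the scatter) that stays within the scatter. Compound 3 is estimated at 2000 nM, with a range from 800 nM to 5000 nM.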

Compound 3, concentration for 50% growth inhibition: 280 nM
The estimate for compound 3 lay 7.1-fold (0.85 log units) above the measured number, outside the stated range (below it).
By their numbers in this assay, from the lowest: compound 3; then compounds 2 and 1 (each within the scatter of the next).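

On this saturated ring carbon, the group carried by the phenyl ring does matter in this assay: chloro in place of methoxy gives a 7.1-fold lower number from compound 2 to compound 3 (0.85 log units; beyond the scatter) and 4-chlorophenyl in place of 2-hydroxyphenyl gives a 7.3-fold lower number from compound 1 to compound 3 (0.86 log units; beyond the scatter) in the same direction. Compounds 1 and 2 could not be told apart, so their pair alone gave no sign that this ring could shift growth inhibition, whereas compound 3 shows that one small exchange on an aromatic carbon, with a single chlorine atom entering where a methoxy leaves, is enough to move the number beyond the scatter. Nothing available explains the gain in growth inhibition, so the result stands as an observation without a known cause.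

A bromo or a fluoro in the same place would test whether the lower number belongs to chloro alone or extends to other halogens, and an amine or a nitrile there would widen the comparison to quite different groups. A plain hydrogen in that place would show whether chloro improves on the bare phenyl ring or methoxy merely falls short of it.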